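This account rests on a few compounds, and the source may have more. Where it says the series, first, only, none or still open, it means among the compounds named here.

Compound 3 `COc1cc(-c2nn(-c3cccc(NC(=O)Nc4ccc(Cl)c(Cl)c4)c3)cc2-c2ccncc2)ccc1Cl` gives the lowest of the three numbers at hand in a functional assay on SW-620 cells (Homo sapiens) for inhibition, read by sulforhodamine B assay, with a stated time of 48 h (a higher number here means a weaker inhibitor of growth, a lower number a stronger inhibitor of growth), with 1590 nM. Its nearest neighbour is compound 2 `COc1cc(-c2nn(-c3cccc(NC(=O)c4cccc(C(F)(F)F)c4)c3)cc2-c2ccncc2)ccc1Cl`, which in this assay gives 2310 nM; the step of a 1.5-fold lower number from compound 2 to compound 3 (0.16 log units; within the scatter) lies within the scatter. Furthest off is compound 1 `O=C(Nc1cccc(-n2cc(-c3ccncc3)c(-c3ccc(Cl)c(O)c3)n2)c1)Nc1cccc(C(F)(F)F)c1`, which in this assay gives 3830 nM, a gap beyond the scatter.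

Compound 4 `O=C(Nc1cccc(-n2cc(-c3ccncc3)c(-c3ccc(Cl)c(O)c3)n2)c1)Nc1ccc(Cl)c(Cl)c1` differs from compound 3 by hydrogen in place of methyl on an oxygen on an aromatic ring, that is methoxy to hydroxy on the 4-chloro-3-methoxyphenyl group. Going by the values given here, no measured pair isolates this change: compound 1 carries the hydroxy group but also differs from compound 3 in the aryl on the urea, so its value and that of compound 3 show only that the two together give a higher number in this assay. Among the compounds with values here, the one measured step, from compound 2 to compound 3, concerns the other end of the molecule. He therefore expects for compound 4 a step of a 1.6-fold higher number from compound 3 to compound 4 (0.20 log units; within the scatter), not beyond the scatter in either direction, and estimates a value of 2500 nM, between 900 nM and 6500 nM.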

Compound 4, concentration for 50% growth inhibition: 1460 nM
Compound 4: the middle estimate sits 1.7-fold (0.23 log units) above what was measured; the measured number falls inside the stated range.
By their numbers in this assay, from the lowest: compounds 4, 3, 2 and 1 (each within the scatter of the next, the first and the last beyond it).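

In this assay, the step from methoxy to hydroxy on the 4-chloro-3-methoxyphenyl group can now be read on its own, and it comes to a 1.1-fold lower number from compound 3 to compound 4 (0.04 log units; within the scatter), so with 3,4-dichlorophenyl on the amide-type nitrogen the two groups cannot be told apart. With the hydroxy group held fixed, 3,4-dichlorophenyl in place of 3-(trifluoromethyl)phenyl on that nitrogen gives a 2.6-fold lower number from compound 1 to compound 4 (0.42 log units; beyond the scatter), and of these two single changes only this one lies beyond the scatter. Nothing at hand gives a reason for either result.

The compounds shown leave open whether the methoxy and hydroxy groups also match when 3-(trifluoromethyl)phenyl sits on the amide-type nitrogen. They also leave open how an ethoxy group or an amine would compare on that oxygen-bearing ring carbon.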